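Fluoro for hydrogen in a cytotoxicity series

The source may hold more compounds than are shown below. What is called first, only, known or untested is meant among the compounds shown, and "the series" means these compounds.

Compound 1 `CC(C)=CCC[C@@](C)(/C=C/c1ccccc1)/C=C/c1ccc(O)cc1` is measured in a functional assay on Raji cells (Homo sapiens) for cytotoxicity, with a stated time of 72 h; a lower number here means that less compound is needed, a higher number that more compound is needed for the effect. In this assay compound 1 gives > 26000 nM, a limit of the assay. Compound 2 `CC(C)=CCC[C@](C)(/C=C/c1ccc(O)cc1)/C=C/c1cccc(F)c1` differs by fluoro in place of hydrogen on an aromatic carbon. In this assay compound 2 gives > 26000 nM, again a limit. So the step reads a step that the two limits leave unreadable from compound 1 to compound 2. Compound 3 `C=C[C@@](C)(/C=C/c1ccc(Nc2ccc(F)cc2)cc1)CCC=C(C)C` has a different core; the difference between the two cores is not broken down here. In this assay compound 3 gives > 26000 nM, also a limit. All measured values share (the limit of > 26000 nM in this assay, at which 3 of the 3 values shown sit). Compound 4 `C=C[C@@](C)(/C=C/c1ccc(Nc2ccc(F)c(F)c2)cc1)CCC=C(C)C` differs from compound 3 by fluoro in place of hydrogen on an aromatic carbon, the same kind of change as from compound 1 to compound 2, though here the place is ortho to a fluoro group as well as meta to a large group. With no readable step available, compound 4 is expected to stay at the limit, an expected step that the limit leaves unreadable from compound 3 to compound 4. The estimate for compound 4 is 40000 nM, from 15000 nM to 120000 nM.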

Compound 4, half-maximal effective concentration: > 26000 nM
Compound 4 gave a limit, no number; the forecaster's own chance of this, stated with the estimate: 85%; the middle value is on the limit's open side.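

Compound 3 and compound 4 both sit at a limit of the assay, so no step between them can be read, and the same holds for compound 1 and compound 2: the limit of > 26000 nM in this assay, at which 4 of the 4 values shown sit.

The compounds shown leave open whether any change here moves cytotoxicity in this assay.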